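A few compounds are considered here, and "the series" means these few. Any claim that something is new, unique, unknown or untested is made for them only; others in the source may bear on it.

Measured so far, read in an assay on HEK293 cells for agonist activity at Bile acid receptor (Homo sapiens), read by a luciferase reporter; on this read-out lower numbers stand for an effect already at smaller amounts and higher numbers for an effect only at larger amounts of compound:

compound 1 `CC(C)OC(=O)C1CN(C(=O)c2ccc(F)cc2)CC(C)(C)c2cc(C#N)[nH]c21` — 640 nM
compound 2 `CC(C)OC(=O)C1=CN(C(=O)c2ccc(F)c(F)c2)CC(C)(C)c2cc(C#N)[nH]c21` — 6.3 nM
compound 3 `CC(C)OC(=O)C1CN(C(=O)C2CCOCC2)CC(C)(C)c2cc(C#N)[nH]c21` — 3300 nM

Compound 2 has the lowest number of the three in this assay: its gap to the nearest, compound 1, and its gap to the furthest, compound 3, both lie beyond the scatter. Compound 1 and compound 2 differ at two places, so their gap cannot be assigned to one of them.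

The next compound, compound 4 `CC(C)OC(=O)C1=CN(C(=O)c2cccs2)CC(C)(C)c2cc(C#N)[nH]c21`, keeps the core of compound 2 and changes only the group on the carbonyl carbon: thiophen-2-yl in place of 3,4-difluorophenyl on a carbonyl carbon. Among the measured compounds shown here, the one measured step at this carbonyl carbon is a 5.2-fold higher number from compound 1 to compound 3 (0.71 log units; beyond the scatter), an aromatic ring giving way to a saturated one. Here one aromatic ring gives way to another, so a smaller shift is expected in this assay, more likely toward a higher number than a lower one, and possibly within the scatter. The expected step is a 2.4-fold higher number from compound 2 to compound 4 (0.38 log units; beyond the scatter). For compound 4 the estimate in this assay is 15 nM, with a range from 4 nM to 60 nM.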

Compound 4, half-maximal effective concentration: 16 nM
Beside the measured number, compound 4's estimate is 1.1-fold (0.03 log units) below it; the measured number falls inside the stated range.
By their numbers in this assay, from the lowest: compound 2; then compound 4; then compound 1; then compound 3.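

At this carbonyl carbon, the shared core of compound 2 and compound 4 accepts a five-membered aromatic ring with one sulfur at a modest cost in this assay: a 2.5-fold higher number from compound 2 to compound 4 (0.40 log units; beyond the scatter). With a 5.2-fold higher number from compound 1 to compound 3 (0.71 log units; beyond the scatter), both single changes read so far at this carbonyl carbon move to a higher number and none goes against this, although the two steps sit on different cores and replace different groups. No measurement shown accounts for the step.

The change from 3,4-difluorophenyl to thiophen-2-yl alters ring size, ring atoms and fluorine content together, so the compounds shown do not separate these contributions. Plain phenyl, furan-2-yl or pyridin-3-yl on this carbonyl carbon would help to divide the step among them.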